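Swapping benzyl for methyl ester on a pyran scaffold

The compounds below may be only part of what the source reports. "The series", "measured", "known", "first", "only" and "open" are said of these compounds alone.

Four compounds share a saturated oxygen-containing ring carrying an unsaturated ester side chain, and they differ in what protects the ring hydroxyl, in the geometry of the double bond, and in the ester alcohol part. Compound 1 `O=C(/C=C/[C@H]1OCCC[C@H]1O)OCc1ccccc1` has a free hydroxyl and a benzyl ester. In a functional assay on SW1573 cells (Homo sapiens) for antiproliferative activity, read by sulforhodamine B assay, with a stated time of 48 h (on this read-out higher numbers stand for weaker inhibition of growth and lower numbers for stronger inhibition of growth), compound 1 reaches only the limit of the assay, > 100000 nM. Compound 2 `CC(C)(C)[Si](C)(C)O[C@@H]1CCCO[C@@H]1/C=C\C(=O)OCc1ccccc1` carries a silyl-protected hydroxyl and a benzyl ester; in this assay compound 2 gives 26000 nM. Compound 3 `COC(=O)/C=C\[C@H]1OCCC[C@H]1O[Si](C)(C)C(C)(C)C` keeps the same protected core but is the methyl ester, and compound 3 gives 6300 nM. The change between them is hydrogen in place of phenyl on a saturated chain carbon bound to an oxygen next to a carbonyl group, and it brought a 4.1-fold lower number from compound 2 to compound 3 (0.62 log units; beyond the scatter). How the core of compound 1 differs from that of compound 2 is not broken down here.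

Compound 4 `COC(=O)/C=C/[C@H]1OCCC[C@H]1O` is not yet measured. It is made from compound 1 by the same change, (hydrogen in place of phenyl on a saturated chain carbon bound to an oxygen next to a carbonyl group). If that change acted as it did between compound 2 and compound 3, compound 4 would be expected to sit somewhat below the starting point; the expected step is an at least 1.2-fold lower number from compound 1 to compound 4 (0.09 log units; that floor lies within the scatter). Because compound 1 sits at the limit of > 100000 nM in this assay, at which 1 of the 3 values shown sits, the starting point is itself uncertain, and compound 4 may again return only a limit. Compound 4 is therefore estimated at 80000 nM, with a range from 20000 nM to 300000 nM.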

Compound 4, concentration for 50% growth inhibition: > 100000 nM
Compound 4: only a limit was reported; the forecaster's own chance of this, stated with the estimate: 50%; middle value at least 1.2-fold (0.09 log units) from the limit.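

Compound 1 and compound 4 both return only a limit in this assay, so the change from phenyl to hydrogen between them has no readable size: the limit of > 100000 nM in this assay, at which 2 of the 4 values shown sit.

The compounds shown leave open whether this change lowers the number on the core of compound 1 as it does on the silyl-protected core of compound 2 and compound 3.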